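This account rests on a few compounds, and the source may have more. Where it says the series, first, only, none or still open, it means among the compounds named here.

Values in an in vitro ADME assay on microsomes from liver (Homo sapiens) for pharmacokinetics, read by LC-MS, with a stated time of 10 min, tested at 1 uM (on this read-out higher numbers stand for fast clearance and lower numbers for slow clearance), so far

Compound 1 `CN1C[C@H](C(=O)Nc2ccc(F)cc2)[C@@H](c2ccc(/C=C/C(=O)Nc3ccccc3N)cc2)C1` gives 5 mL/min/kg
Compound 2 `COc1ccc(NC(=O)[C@H]2CN(C)C[C@@H]2c2ccc(/C=C/C(=O)Nc3ccccc3N)cc2)cc1` gives 14 mL/min/kg
Compound 3 `CN1C[C@H](C(=O)Nc2ccc(C#N)cc2)[C@@H](c2ccc(/C=C/C(=O)Nc3ccccc3N)cc2)C1` gives 1 mL/min/kg

Of these three, compound 3 has the lowest number, and both others lie beyond the scatter above it. The next compound, compound 4 `CC(C)c1ccc(NC(=O)[C@H]2CN(C)C[C@@H]2c2ccc(/C=C/C(=O)Nc3ccccc3N)cc2)cc1`, keeps the shared core and changes one group, with isopropyl in place of cyano on an aromatic carbon. Going by the values given here, three measured steps bear on this, all made at that same place. Methoxy in place of fluoro gave a 2.8-fold higher number from compound 1 to compound 2 (0.45 log units; beyond the scatter), cyano in place of fluoro gave a 5.0-fold lower number from compound 1 to compound 3 (0.70 log units; beyond the scatter), and cyano in place of methoxy gave a 14-fold lower number from compound 2 to compound 3 (1.15 log units; beyond the scatter). Among these compounds, cyano goes with the lowest number, and no compound here goes against that. Isopropyl itself has no measurement yet, so the size remains uncertain. Removing cyano should still raise the number, judging by compound 2 at 14 mL/min/kg and compound 1 at 5 mL/min/kg. The expected change is a 12-fold higher number from compound 3 to compound 4 (1.08 log units; beyond the scatter). Compound 4 is estimated at 12 mL/min/kg, with an expected range from 4 mL/min/kg to 35 mL/min/kg.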

Compound 4, clearance: 10 mL/min/kg
Beside the measured number, compound 4's estimate is 1.2-fold (0.08 log units) above it; measured number inside the range.
By their numbers in this assay, from the lowest: compound 3; then compounds 1, 4 and 2 (each within the scatter of the next, the first and the last beyond it).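

In this assay, isopropyl in place of cyano gives a 10-fold higher number from compound 3 to compound 4 (1.00 log units; beyond the scatter), so compound 3 now stands apart from three compounds with other groups at this position on the aromatic ring. Isopropyl does not separate from either earlier group, with a 1.4-fold lower number from compound 2 to compound 4 (0.15 log units; within the scatter) and a 2.0-fold higher number from compound 1 to compound 4 (0.30 log units; within the scatter), both within the scatter, although fluoro and methoxy remain apart, with a 2.8-fold higher number from compound 1 to compound 2 (0.45 log units; beyond the scatter). Nothing measured here explains why cyano goes with the lowest number.

The compounds shown leave open whether cyano is alone in giving such a low number, since a carboxylic acid, an amine or a trifluoromethyl group at this position could fall near compound 3 or near the others. They also leave open whether a longer chain in place of isopropyl would stay with compound 4.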